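Notes on the benzylsulfanyl variation leading to compound 4

A few compounds are considered here, and "the series" means these few. Any claim that something is new, unique, unknown or untested is made for them only; others in the source may bear on it.

Compound 1 `Cc1cc(-c2ccccc2)n(/C(N)=N/S(=O)(=O)c2cc(C)c(Cl)cc2SCc2cccc3ccccc23)n1` gives 170000 nM in a functional assay on MCF7 cells (Homo sapiens) for cytotoxicity, read by MTT assay, with a stated time of 72 h (on this read-out lower numbers stand for stronger inhibition and higher numbers for weaker inhibition), the highest of the three numbers shown. Compound 2 `Cc1cc(S(=O)(=O)/N=C(\N)n2nccc2-c2ccccc2)c(SCc2cccc3ccccc23)cc1Cl` gives 58000 nM, a step of a 2.9-fold lower number from compound 1 to compound 2 (0.47 log units; beyond the scatter); compound 3 `Cc1cc(S(=O)(=O)/N=C(\N)n2nccc2-c2ccccc2)c(SCc2cccc(C(F)(F)F)c2)cc1Cl` gives 17000 nM, a step of a 3.4-fold lower number from compound 2 to compound 3 (0.53 log units; beyond the scatter). Compound 4 `Cc1cc(-c2ccccc2)n(/C(N)=N/S(=O)(=O)c2cc(C)c(Cl)cc2SCc2ccccc2)n1` differs from compound 1 by phenyl in place of naphthalen-1-yl on a saturated chain carbon bound to a sulfur. Among the compounds with values here, only the step of a 3.4-fold lower number from compound 2 to compound 3 (0.53 log units; beyond the scatter) bears on this change: it too replaces the naphthalen-1-yl group on the saturated chain carbon bound to a sulfur, though the entering group there carries a trifluoromethyl, whereas here it is plain phenyl. The step of a 2.9-fold lower number from compound 1 to compound 2 (0.47 log units; beyond the scatter) concerns a different site. A modest lowering is therefore expected, a 1.9-fold lower number from compound 1 to compound 4 (0.28 log units; within the scatter), with the unlike entering group leaving the direction uncertain. Compound 4 is estimated at 90000 nM, with a range of 30000 nM to 250000 nM.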

Compound 4, half-maximal inhibitory concentration: 15000 nM
Compound 4: the middle estimate sits 6.0-fold (0.78 log units) above what was measured; the whole stated range lies above it.
By their numbers in this assay, from the lowest: compounds 4 and 3 (each within the scatter of the next); then compound 2; then compound 1.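

In this assay, plain phenyl in place of naphthalen-1-yl on the saturated chain carbon bound to a sulfur gives an 11-fold lower number from compound 1 to compound 4 (1.05 log units; beyond the scatter) and is a large change. The trifluoromethyl is therefore not needed for a lowering at this position: a 3.4-fold lower number from compound 2 to compound 3 (0.53 log units; beyond the scatter) runs the same way, with 3-(trifluoromethyl)phenyl entering on a different background. Nothing shown gives a cause for the size of this step.

Still open, as far as these compounds go, is whether plain phenyl gives a step of similar size on compound 2. Also open, from the compounds shown here alone, is how an amine or a carboxylic acid on the phenyl ring, or a longer chain before it, would read here.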